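The compounds below may be only part of what the source reports. "The series", "measured", "known", "first", "only" and "open" are said of these compounds alone.

Compound 2 `O=C(Nc1cccc(-n2cc(-c3ccncc3)c(-c3ccc(Cl)c(O)c3)n2)c1)Nc1cc(C(F)(F)F)cc(C(F)(F)F)c1` gives 395 nM in a functional assay on OVCAR-3 cells (Homo sapiens) for inhibition, read by sulforhodamine B assay, with a stated time of 48 h (on this read-out lower numbers stand for stronger inhibition of growth and higher numbers for weaker inhibition of growth), and stands lowest of the three measured numbers. Compound 3 `COc1cc(-c2nn(-c3cccc(NC(=O)Nc4ccc(Cl)c(C(F)(F)F)c4)c3)cc2-c2ccncc2)ccc1Cl` gives 889 nM and compound 1 `COc1cc(-c2nn(-c3cccc(NC(=O)c4cccc(C(F)(F)F)c4)c3)cc2-c2ccncc2)ccc1Cl` gives 1200 nM, both beyond the scatter above compound 2, so compound 2 is the most potent measured here. Compound 4 `O=C(Nc1cccc(-n2cc(-c3ccncc3)c(-c3ccc(Cl)c(O)c3)n2)c1)Nc1cccc(C(F)(F)F)c1` differs from compound 2 by hydrogen in place of trifluoromethyl on an aromatic carbon. For the measured compounds named here, the one measured step, a 1.3-fold lower number from compound 1 to compound 3 (0.13 log units; within the scatter), altered the group on the carbonyl carbon and stayed within the scatter; no measured step removes a trifluoromethyl, so it bears only loosely on this change. A small rise in the number, that is slightly weaker growth inhibition, is expected for compound 4, a 1.5-fold higher number from compound 2 to compound 4 (0.18 log units; within the scatter). Compound 4 is estimated at 600 nM, with a range from 250 nM to 1500 nM.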

Compound 4, concentration for 50% growth inhibition: 1060 nM
Compound 4: the middle estimate sits 1.8-fold (0.25 log units) below what was measured; low and high end bracket the measured number.
By their numbers in this assay, from the lowest: compound 2; then compounds 3, 4 and 1 (each within the scatter of the next).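

Putting hydrogen in place of trifluoromethyl, on an aromatic carbon meta to a second trifluoromethyl group, produces a 2.7-fold higher number from compound 2 to compound 4 (0.43 log units; beyond the scatter) and so weakens growth inhibition. For the compounds shown here, the only earlier step changed the group on a carbonyl carbon and stayed within the scatter, whereas this pair shows that the aromatic position itself can move the number beyond it. No measurement given here accounts for the loss of activity. As far as these compounds go, whether trifluoromethyl is specifically needed at this position remains open: a methyl or a nitrile there would test that.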